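Notes on pairing the chlorophenyl pieces of compounds 1 and 2

A few compounds are considered here, and "the series" means these few. Any claim that something is new, unique, unknown or untested is made for them only; others in the source may bear on it.

Compound 1 `Cc1nc(Nc2ccc(Cl)cc2)sc1C(=O)/C=C/c1ccccc1` was tested in a functional assay on NCI-H460 cells (Homo sapiens) for cytotoxicity, read by MTT assay; a lower number here means a stronger inhibitor, a higher number a weaker inhibitor. Compound 1 gives > 25000 nM there, a limit of the assay and not a number. Compound 2 `Cc1ccccc1Nc1nc(C)c(C(=O)/C=C/c2ccc(Cl)cc2)s1` gives > 25000 nM in this assay, again only a limit of the assay. For the measured compounds named here, compound 2 therefore stands at the limit, and the one further value shown is a limit too, since the limit of > 25000 nM in this assay, at which 2 of the 2 values shown sit, holds both values. Going by the values given here, no step between measured compounds can be sized.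

Compound 3 `Cc1nc(Nc2ccc(Cl)cc2)sc1C(=O)/C=C/c1ccc(Cl)cc1` carries 4-chlorophenyl in place of 2-methylphenyl on a nitrogen on an aromatic ring; cut one bond further out, (2-methylphenyl)amino becomes (4-chlorophenyl)amino. Compound 3 thus joins the arylamino group of compound 1 with the rest of compound 2, and both of those sit at the limit. In this assay no step beyond the usual scatter is expected in either direction, and compound 3 is expected to return a limit as well. The estimate for compound 3 is 30000 nM, with a range of 10000 nM to 90000 nM. That means an expected step that the limit leaves unreadable from compound 2 to compound 3.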

Compound 3, half-maximal inhibitory concentration: > 25000 nM
Compound 3 gave a limit, no number; the forecaster's own chance of this, stated with the estimate: 75%; the middle value lies beyond the limit too.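

For the compounds shown here, compound 3 ends at a limit, as compound 1 and compound 2 do, so no step from either of them to compound 3 can be read: the limit of > 25000 nM in this assay, at which 3 of the 3 values shown sit. The compounds shown leave open which change to the shared core, if any, would give a readable number in this assay.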